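The compounds below may be only part of what the source reports. "The series", "measured", "known", "first", "only" and "open" are said of these compounds alone.

Series notes. Three compounds of the shared core have been run in a functional assay on A549 cells (Homo sapiens) for inhibition, read by MTT assay, with a stated time of 72 h; a lower number here means a stronger inhibitor, a higher number a weaker inhibitor. Going by the values given here, compound 1 `COc1cc(O)c(CC=C(C)C)c(O)c1C(=O)/C=C/c1ccc(O)c(O)c1` gives 16100 nM there and is the only member with a measured number. Compound 2 `COc1cc(/C=C/C(=O)c2c(OC)cc(O)c(CC=C(C)C)c2O)cc(OC)c1OC` returns a limit of > 50000 nM in this assay. Compound 3 `COc1cc(O)cc(O)c1C(=O)/C=C/c1ccc(O)cc1` likewise returns a limit of > 50000 nM in this assay. Compound 3 thus stands at the limit of > 50000 nM in this assay, at which 2 of the 3 values shown sit; no number exists for it, only the limit.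

Compound 4 `COc1cc(O)cc(O)c1C(=O)/C=C/c1ccc(C)cc1` is next in this assay. It differs from compound 3 by methyl in place of hydroxy on an aromatic carbon. Compound 3 is already at the limit. The step is therefore expected to be none beyond the scatter or a further weakening. Among the compounds with values here, the one measured number in the set, that of compound 1 at 16100 nM, gives no ground to expect a gain when a hydroxy is exchanged for a methyl. For compound 4 the expected step is a step that the limit leaves unreadable from compound 3 to compound 4. Compound 4 is therefore estimated at 70000 nM, in a range of 25000 nM to 200000 nM, with another limit the likeliest result.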

Compound 4, half-maximal inhibitory concentration: > 50000 nM
Compound 4: only a limit was reported (the forecaster's own chance of this, stated with the estimate: 80%); the middle value is on the limit's open side.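

Compound 3 and compound 4 both stand at a limit, so no step can be read between them: the limit of > 50000 nM in this assay, at which 3 of the 4 values shown sit.

The compounds shown leave open how hydroxy and methyl on this aromatic carbon compare, as neither compound has a measured number.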